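Cyclopropylamino in Place of Hydroxyethylamino on a Triazolopyrimidine Core

The source may hold more compounds than are shown below. What is called first, only, known or untested is meant among the compounds shown, and "the series" means these compounds.

Compound 1 `OCCNc1nc(-c2ccccc2)nc2c1nnn2Cc1ccccc1`: 38000000 nM
Compound 2 `Clc1ccccc1Cn1nnc2c(NC3CCC3)nc(-c3ccccc3)nc21`: 24000000 nM
Compound 3 `Clc1ccccc1Cn1nnc2c(NC3CCCC3)nc(-c3ccccc3)nc21`: 9000000 nM

Three measured compounds share a core and differ in the group on the ring nitrogen and in the benzyl substituent. In an assay on isolated protein for binding affinity to adenosine receptor A1 (Bos taurus) (a lower number here means a stronger inhibitor, a higher number a weaker inhibitor), compound 1 gives 38000000 nM, the top of the range shown. Among the measured compounds shown here, compound 2, carrying cyclobutyl and a chlorinated benzyl, lies within the scatter of compound 1, while compound 3 lies beyond it: the only single-point step, a 2.7-fold lower number from compound 2 to compound 3 (0.43 log units; beyond the scatter), is modest.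

Compound 4 `c1ccc(Cn2nnc3c(NC4CC4)nc(-c4ccccc4)nc32)cc1` takes the step (cyclopropyl in place of 2-hydroxyethyl on a nitrogen on an aromatic ring). For the measured compounds named here, no measured step covers this exchange directly; the nearest guide is that compound 1 and compound 2, which differ both in the amine group and in the benzyl substituent, sit within the scatter of each other, while the ring enlargement from compound 2 to compound 3 gave only a modest shift. A small ring entering in place of 2-hydroxyethyl is therefore expected to move this assay little, if at all beyond the scatter, with a slight lean toward a lower number, so that a 1.3-fold lower number from compound 1 to compound 4 (0.10 log units; within the scatter) is the expected step. Compound 4 is estimated at 30000000 nM, within 8000000 nM to 100000000 nM.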

Compound 4, inhibition constant: 11000000 nM
Compound 4: middle estimate off by 2.7-fold (0.44 log units), on the high side; low and high end bracket the measured number.
By their numbers in this assay, from the lowest: compounds 3 and 4 (each within the scatter of the next); then compounds 2 and 1 (each within the scatter of the next).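

Among the compounds shown here, the step of a 3.5-fold lower number from compound 1 to compound 4 (0.54 log units; beyond the scatter) in this assay is the first single-place reading of what happens when 2-hydroxyethyl leaves this nitrogen, and it shows that the exchange for cyclopropyl moves the number beyond the scatter, even though the heavy-atom count of the group stays the same and its hydrogen-bond donor and acceptor are lost. For the compounds shown here, until now the only single-place step at this nitrogen was a 2.7-fold lower number from compound 2 to compound 3 (0.43 log units; beyond the scatter), which swapped one carbon ring for another, so the position is now seen to respond also when an open chain gives way to a ring, with compound 4 still at 11000000 nM and a step that is likewise modest. The data shown offer nothing that accounts for this shift.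

The compounds shown leave open whether the lower number follows from the loss of the hydroxyl or from the arrival of the ring, a question that an ethyl or a 2-methoxyethyl group on the same nitrogen would help to separate. They also leave open how the chlorinated benzyl and the unsubstituted benzyl compare when the amine group is held the same, and whether a cyclohexyl group would continue the trend among the carbon rings.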